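Pyrimidine-fused lactam series: alkyl trimming on the solubilising amide

The source may hold more compounds than are shown below. What is called first, only, known or untested is meant among the compounds shown, and "the series" means these compounds.

Measured so far in a functional assay on HeLa cells (Homo sapiens) for antiproliferative activity, read by CCK-8 assay, with a stated time of 72 h; on this read-out lower numbers stand for stronger inhibition of growth and higher numbers for weaker inhibition of growth:
- compound 1, `CCC1C(=O)N(C)c2cnc(Nc3ccc(S(=O)(=O)NC)cc3)nc2N1c1ccn(C)n1`: 2200 nM
- compound 2, `CCCNS(=O)(=O)c1ccc(Nc2ncc3c(n2)N(c2ccn(C)n2)C(CC)C(=O)N3C)cc1`: 2670 nM
- compound 3, `CCCCNC(=O)c1ccc2c(ccn2-c2ncc3c(n2)N(c2ccn(C)n2)C(CC)C(=O)N3C)c1`: 4260 nM

Compound 1 and compound 2 carry the same shared core and differ only at the sulfonamide end. The change from compound 2 to compound 1 is hydrogen in place of ethyl on a saturated chain carbon bound to a sulfonamide nitrogen. Its effect, a 1.2-fold lower number from compound 2 to compound 1 (0.08 log units; within the scatter), is small, so the two values cannot be told apart in this assay.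

Compound 3 differs from compound 2 in more than one place; the difference between the two cores is not broken down here. Among the three measured compounds, compound 3 gives the highest number, but its distances to compound 2 and to compound 1 both lie within the scatter, so no order is claimed.

Compound 4, `CCNC(=O)c1ccc2c(ccn2-c2ncc3c(n2)N(c2ccn(C)n2)C(CC)C(=O)N3C)c1`, has not yet been measured. It arises from compound 3 by hydrogen in place of ethyl on a saturated chain carbon, two bonds along the chain from an amide-type nitrogen. Among the measured compounds shown here, this is the same kind of change as the one from compound 2 to compound 1, not the same: there the ethyl sat on a saturated chain carbon bound to a sulfonamide nitrogen, here it sits on a saturated chain carbon, two bonds along the chain from an amide-type nitrogen. For the measured compounds named here, with only one precedent, the expectation is that compound 4 moves by about a 1.2-fold lower number from compound 3 to compound 4 (0.07 log units; within the scatter), a step estimated to be about as small as the earlier one because a 1.2-fold lower number from compound 2 to compound 1 (0.08 log units; within the scatter) showed trimming the chain to be nearly neutral. Compound 4 is therefore expected to give roughly 3600 nM in this assay, with a range from 1800 nM to 7500 nM.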

Compound 4, concentration for 50% growth inhibition: 11100 nM
For compound 4 the middle estimate is 3.1-fold (0.49 log units) below the measured one; the measured number lies above the stated range.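

In this assay, the trim from butyl to ethyl on the amide side gives a 2.6-fold higher number from compound 3 to compound 4 (0.42 log units; beyond the scatter), so on this core the shorter chain weakens growth inhibition, whereas the same kind of trim on the sulfonamide side made no readable difference. The change therefore cannot be carried from one core to the other at a single size: the same change on two cores in this assay, a 1.2-fold lower number (0.08 log units; within the scatter) from compound 2 to compound 1 and a 2.6-fold higher number (0.42 log units; beyond the scatter) from compound 3 to compound 4, 3.2-fold (0.50 log units) apart, beyond the scatter of two such steps This rests on one pair per core: it shows that the size of the step depends on where it is made, but not which of the several differences between the two cores is responsible, and it gives no general rule for chain length across the series.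

Left open is the shape of the chain-length trend on the amide side, where a propyl or a pentyl chain in place of the butyl of compound 3 would show whether the step is gradual or abrupt, and an amine or a carboxylic acid carried on that chain would show whether the chain's carbon count alone sets the number. Also open, from the compounds shown here alone, is whether the sulfonamide side stays flat over a wider range, which a butyl chain in place of the propyl of compound 2 would test.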